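Phenyl for methoxycarbonyl on the hydroxyl-bearing carbon

A few compounds are considered here, and "the series" means these few. Any claim that something is new, unique, unknown or untested is made for them only; others in the source may bear on it.

Compound 1 `CC(C)(C)C1=C(C(=O)O)N2C(=O)[C@H]([C@H](O)c3ccccc3)[C@H]2O1`: in an ADME assay, in phosphate buffer, at 28 degrees C, at pH 7.0 (a lower number here means that the compound disappears faster, a higher number that the compound lasts longer), compound 1 gives 7 h.
Compound 2 `C[C@H](O)[C@H]1C(=O)N2C(C(=O)O)=C(C(C)(C)C)O[C@H]12`: in this assay compound 2 gives 7.1 h.
Compound 3 `COC(=O)[C@H](O)[C@H]1C(=O)N2C(C(=O)O)=C(C(C)(C)C)O[C@H]12`: in this assay compound 3 gives 6.7 h.

All three compounds share the same core and differ only in the group on the saturated chain carbon that carries the hydroxyl. In this assay compound 3 sits at the same level as compound 1 and compound 2; its gaps to both are within the scatter.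

Compound 4 `CC(C)(C)C1=C(C(=O)O)N2C(=O)[C@H]([C@@H](O)c3ccccc3)[C@H]2O1` is not yet measured. It differs from compound 3 in one place: phenyl in place of methoxycarbonyl on a saturated chain carbon bound to an oxygen on a saturated carbon and a saturated ring carbon.

One measured step changes the group at this same carbon: a 1.1-fold lower number from compound 2 to compound 3 (0.03 log units; within the scatter). Compound 1, which carries a phenyl at this carbon, gives a number that matches compound 3 within the scatter. Nothing in these data points to a step beyond the scatter, so compound 4 is expected to stay at the level of compound 3, which means a 1.0-fold higher number from compound 3 to compound 4 (0.02 log units; within the scatter).

The estimate for compound 4 in this assay is therefore 7 h, with a range from 4 h to 12 h.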

Compound 4, half-life: 8.9 h
For compound 4 the middle estimate is 1.3-fold (0.10 log units) below the measured one; measured number inside the range.
By their numbers in this assay, from the lowest: compounds 3, 1, 2 and 4 (each within the scatter of the next).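

In this assay, a bulky aromatic ring at this carbon reads no differently from the ester it replaces, with phenyl in place of methoxycarbonyl giving a 1.3-fold higher number from compound 3 to compound 4 (0.12 log units; within the scatter). Phenyl in place of methyl gives the same picture, a 1.3-fold higher number from compound 2 to compound 4 (0.10 log units; within the scatter), so methyl, methoxycarbonyl and phenyl on this saturated chain carbon all stay within the scatter of one another. Within the data shown here, the result also gives a first look at the spatial arrangement at this carbon, a 1.3-fold higher number from compound 1 to compound 4 (0.10 log units; within the scatter), again within the scatter, and this comparison isolates that single feature: the fact that compounds 1 and 4 differ only in the configuration as drawn.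

The compounds shown leave open whether an amine, a carboxylic acid or a longer chain on this carbon would move the half-life beyond the scatter. They also leave open whether the configuration here counts for as little with methyl or methoxycarbonyl as it does with phenyl.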